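Hydroxy in place of amino in compound 3

The source may report more compounds than this note shows. Statements on the series, on what has been measured and on what is new or still open speak of the compounds shown alone.

In a functional assay on HCT-15 cells (Homo sapiens) for antiproliferative activity, read by MTT assay, with a stated time of 72 h (on this read-out lower numbers stand for stronger inhibition and higher numbers for weaker inhibition), compound 3 `COc1ccc(-n2ccnc2-c2cc(OC)c(OC)c(OC)c2)cc1N` gives 100 nM, the lowest of the three measured numbers, against compound 1 `COc1ccc(-n2ccnc2-c2cc(OC)c(OC)c(OC)c2)cc1[N+](=O)[O-]` at 1000 nM and compound 2 `COc1ccc(-n2ccnc2-c2cc(OC)c(OC)c(OC)c2)cc1` at 1300 nM. Compound 4 `COc1ccc(-n2ccnc2-c2cc(OC)c(OC)c(OC)c2)cc1O` has hydroxy in place of amino on an aromatic carbon, ortho to a methoxy group: hydroxy in place of amino on an aromatic carbon. The measured steps all concern this carbon. Hydrogen in place of nitro stayed within the scatter, a 1.3-fold higher number from compound 1 to compound 2 (0.11 log units; within the scatter), while amino gave a modest step, a 10-fold lower number from compound 1 to compound 3 (1.00 log units; beyond the scatter), and a large one, a 13-fold lower number from compound 2 to compound 3 (1.11 log units; beyond the scatter). Among the compounds with values here, no hydroxy compound has been measured, so the expectation is loose, with no clear step beyond the scatter. The expected change is a 1.2-fold higher number from compound 3 to compound 4 (0.08 log units; within the scatter). The estimated value for compound 4 is 120 nM, within an expected range of 35 nM to 400 nM.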

Compound 4, half-maximal inhibitory concentration: 200 nM
The estimate for compound 4 lay 1.7-fold (0.22 log units) below the measured number; measured number inside the range.
By their numbers in this assay, from the lowest: compounds 3 and 4 (each within the scatter of the next); then compounds 1 and 2 (each within the scatter of the next).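

In this assay, hydroxy and amino on this aromatic carbon cannot be told apart (a 2.0-fold higher number from compound 3 to compound 4 (0.30 log units; within the scatter)), so the lower numbers are not confined to amino. Hydroxy also stands clear of both hydrogen (a 6.5-fold lower number from compound 2 to compound 4 (0.81 log units; beyond the scatter)) and nitro (a 5.0-fold lower number from compound 1 to compound 4 (0.70 log units; beyond the scatter)), which shows that a second group on this carbon, ortho to a methoxy group, separates from those two. No measurement at hand explains what hydroxy and amino share here. Going by these compounds, whether a methylamino group, an acetamido group or a fluorine on this carbon would join hydroxy and amino or fall with hydrogen and nitro stays open.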